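The source may hold more compounds than are shown below. What is called first, only, known or untested is meant among the compounds shown, and "the series" means these compounds.

Of the compounds shown here, two of a shared core have been measured in a functional assay for agonist activity at Alpha-1B adrenergic receptor (Homo sapiens); a higher number here means that more compound is needed for the effect, a lower number that less compound is needed. Compound 1 `CSc1ccc(C)cc1NCC1=NCCN1` gives 0.417 nM in this assay. Compound 2 `CS(=O)(=O)c1ccc(Cl)cc1NCC1=NCCN1` gives 61.7 nM in this assay, the higher of the two numbers, and its distance from compound 1 lies beyond the scatter. Compound 3 `CSc1ccc(Cl)cc1NCC1=NCCN1` differs from compound 2 in one place: methylsulfanyl in place of methylsulfonyl on an aromatic carbon. Going by the values given here, no measured pair isolates this change, yet compound 1 carries the same methylsulfanyl group, so a large step downward is expected, a 41-fold lower number from compound 2 to compound 3 (1.61 log units; beyond the scatter). Compound 3 is estimated at 1.5 nM in this assay, within 0.3 nM to 8 nM.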

Compound 3, half-maximal effective concentration: 0.501 nM
The estimate for compound 3 lay 3.0-fold (0.48 log units) above the measured number; measured number inside the range.
By their numbers in this assay, from the lowest: compounds 1 and 3 (each within the scatter of the next); then compound 2.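

In this assay, with chloro held in place, methylsulfanyl in place of methylsulfonyl on this aromatic carbon gives a 120-fold lower number from compound 2 to compound 3 (2.09 log units; beyond the scatter), so this single change alone has a large effect. By contrast, chloro in place of methyl on an aromatic carbon gives a 1.2-fold higher number from compound 1 to compound 3 (0.08 log units; within the scatter), which stays within the scatter. Nothing available explains the large step. Going by these compounds, whether a methoxy group or a longer ethylsulfanyl chain on this carbon would keep the number as low as methylsulfanyl does remains open. So does how a bromo group or an amine would fare in place of chloro.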